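The source may hold more compounds than are shown below. What is called first, only, known or untested is meant among the compounds shown, and "the series" means these compounds.

Working notes on a small series built around a hindered phenol amide.

Compound 1 `CCOC(=O)C(CS)NC(=O)c1cc(C(C)(C)C)c(O)c(C(C)(C)C)c1` gives 23% in a functional assay, with a stated time of 30 min, tested at 50 uM; a lower number here means a weaker effect, a higher number a stronger effect of the compound at the concentration tested. Compound 2 `CCOC(=O)C(CS)NC(=O)/C=C/c1cc(C(C)(C)C)c(O)c(C(C)(C)C)c1` carries the same side chain on a core that differs from that of compound 1; the difference between the two cores is not broken down here. In this assay compound 2 gives 37%, the strongest effect of the three measured compounds, its steps to both others lying beyond the scatter. Compound 3 `CC(C)(C)c1cc(C(=O)NCCS)cc(C(C)(C)C)c1O` is compound 1 with hydrogen in place of ethoxycarbonyl on a saturated chain carbon bound to an amide-type nitrogen and a saturated chain carbon. In this assay compound 3 gives 20%, so that the change produces a number 3 percentage points lower from compound 1 to compound 3 (within the scatter).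

Compound 4 `CC(C)(C)c1cc(/C=C/C(=O)NCCS)cc(C(C)(C)C)c1O` is not yet measured. It stands to compound 2 as compound 3 stands to compound 1: hydrogen in place of ethoxycarbonyl on a saturated chain carbon bound to an amide-type nitrogen and a saturated chain carbon, the same change on the same kind of chain carbon, made here on the core of compound 2 rather than that of compound 1. Among the compounds shown this change occurs twice in all, and its one measured instance is the step from compound 1 to compound 3.

For the measured compounds named here, for compound 4 the step of a number 3 percentage points lower from compound 2 to compound 4 (within the scatter) from compound 2 in this assay is expected to be small, because a number 3 percentage points lower from compound 1 to compound 3 (within the scatter) was within the scatter, with the caution that the two cores differ and only one instance of the change has been measured. The value of compound 4 in this assay is therefore estimated at 34%, with a range from 22% to 46%.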

Compound 4, a percentage reported as activity, at one concentration (the size of the read-out at that concentration, not a potency): 34%
The estimate for compound 4 equals the measured number at the digits printed; low and high end bracket the measured number.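

Series notes, the ethoxycarbonyl change on a second core. In this assay the replacement of ethoxycarbonyl by hydrogen on the saturated chain carbon bound to an amide-type nitrogen and a saturated chain carbon gives a number 3 percentage points lower from compound 2 to compound 4 (within the scatter) on the core of compound 2, and set beside the earlier instance on the core of compound 1 it reads: the same change on two cores in this assay, a number 3 percentage points lower (within the scatter) from compound 1 to compound 3 and a number 3 percentage points lower (within the scatter) from compound 2 to compound 4, 0 percentage points apart, within the scatter of two such steps. On these two cores, then, the change carries over without a detectable difference, and on neither does the loss of ethoxycarbonyl move the read-out beyond the scatter. For the compounds shown here, this rests on only two pairs in a single assay at a single concentration, so it shows neither that the two steps would match as potencies nor that the change would behave the same way on any other core.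

The compounds shown leave open whether a carboxylic acid or a primary amide in place of ethoxycarbonyl would also stay within the scatter on both cores. They also leave open whether a longer chain than 2-sulfanylethyl, or a hydroxyl group in place of the sulfanyl group, would keep the read-out of these compounds.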